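This account rests on a few compounds, and the source may have more. Where it says the series, first, only, none or still open, it means among the compounds named here.

Working notes on the series measured in a functional assay for inhibition of sodium/hydrogen exchanger (Oryctolagus cuniculus); on this read-out lower numbers stand for stronger inhibition and higher numbers for weaker inhibition. Compound 1 `Cc1cc(F)c(S(C)(=O)=O)cc1C(=O)N=C(N)N` gives 44 nM; compound 2 `Cc1cc(-c2ccco2)c(S(C)(=O)=O)cc1C(=O)N=C(N)N` gives 16 nM; compound 3 `Cc1cc(N2CCC(N)CC2)c(S(C)(=O)=O)cc1C(=O)N=C(N)N` gives 9.8 nM. Compound 3 carries the lowest of the three numbers, though its gap to compound 2 is within the scatter, a 1.6-fold lower number from compound 2 to compound 3 (0.21 log units; within the scatter), while the gap to compound 1 lies beyond it, a 4.5-fold lower number from compound 1 to compound 3 (0.65 log units; beyond the scatter). Compound 4 `Cc1cc(-n2ccc(=O)cc2)c(S(C)(=O)=O)cc1C(=O)N=C(N)N` differs from compound 3 in one place: a group of 7 heavy atoms (5 carbon, 1 nitrogen, 1 oxygen; one six-membered aromatic ring with 1 hetero atom) in place of a group of 7 heavy atoms (5 carbon, 2 nitrogen; one six-membered non-aromatic ring with 1 hetero atom), on an aromatic carbon. Among the measured compounds shown here, the steps that bear on this site are a 2.8-fold lower number from compound 1 to compound 2 (0.44 log units; beyond the scatter) and a 4.5-fold lower number from compound 1 to compound 3 (0.65 log units; beyond the scatter); both replacements of fluoro lowered the number modestly, and the two larger groups sit within the scatter of each other. A small rise in number is therefore expected for compound 4, a 1.5-fold higher number from compound 3 to compound 4 (0.18 log units; within the scatter). Compound 4 is estimated at 15 nM, range 6 nM to 40 nM.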

Compound 4, half-maximal inhibitory concentration: 75 nM
The estimate for compound 4 lay 5.0-fold (0.70 log units) below the measured number; the measured number lies above the stated range.
By their numbers in this assay, from the lowest: compounds 3 and 2 (each within the scatter of the next); then compounds 1 and 4 (each within the scatter of the next).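

The site does not reward every larger group. With equal heavy-atom counts leaving and entering, the change to the aromatic ring with its carbonyl gives (a 7.7-fold higher number from compound 3 to compound 4 (0.88 log units; beyond the scatter)), and the same group set against furan-2-yl gives (a 4.7-fold higher number from compound 2 to compound 4 (0.67 log units; beyond the scatter)). Set against fluoro, it stays within the scatter (a 1.7-fold higher number from compound 1 to compound 4 (0.23 log units; within the scatter)), so the lowering seen with the other two replacements of fluoro does not extend to compound 4, and no data at hand account for the rise.

Going by these compounds, whether the amine of the 4-aminopiperidin-1-yl group or the carbonyl of compound 4 carries this difference stays open. A plain piperidin-1-yl group, without the amine, would help separate the two.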